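The source may hold more compounds than are shown below. What is called first, only, known or untested is meant among the compounds shown, and "the series" means these compounds.

Measured in a functional assay on MDA-MB-231 cells (Homo sapiens) for antiproliferative activity, read by MTT assay, with a stated time of 96 h; on this read-out lower numbers stand for stronger inhibition and higher numbers for weaker inhibition:

- Compound 1 `CC(C)=CCC/C(C)=C/CC/C(C)=C/CC[C@]1(C)CCc2c(C)c(OC(=O)NS(=O)(=O)c3ccc(Cl)cc3)c(C)c(C)c2O1`: > 10000 nM (a limit)
- Compound 2 `CC(C)=CCC/C(C)=C/CC/C(C)=C/CC[C@]1(C)CCc2c(C)c(OC(=O)NCc3ccccc3)c(C)c(C)c2O1`: 7200 nM
- Compound 3 `CC(C)=CCC/C(C)=C/CC/C(C)=C/CC[C@]1(C)CCc2cc(OC(=O)NC(=O)Oc3ccccc3)c(C)c(C)c2O1`: "not determined" (no result reported)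

As far as these compounds go, compound 3 has no number, so its place among the others is unknown. Compound 4 `CC(C)=CCC/C(C)=C/CC/C(C)=C/CC[C@]1(C)CCc2c(C)c(OC(=O)NC(=O)Oc3ccccc3)c(C)c(C)c2O1` differs from compound 3 by methyl in place of hydrogen on an aromatic carbon. Among the compounds with values here, the only measured step, an at least 1.3-fold lower number from compound 1 to compound 2 (0.14 log units; that floor lies within the scatter), is benzyl in place of (4-chlorophenyl)sulfonyl on an amide-type nitrogen, a different change. Within the data shown here, no measured step therefore gives a size or direction for the methyl, and none beyond the scatter is expected. The estimate rests on compound 2 at 7200 nM and on (the limit of > 10000 nM in this assay, at which 1 of the 3 values shown sits). For compound 4 the expected value is 8000 nM, with an estimated range of 3000 nM to 20000 nM.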

Compound 4, half-maximal inhibitory concentration: > 10000 nM
Compound 4 was reported as a limit (the forecaster's own chance of this, stated with the estimate: 45%); middle value at least 1.2-fold (0.09 log units) from the limit.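

In this assay compound 4 gives a limit (> 10000 nM). On the amide-type nitrogen, phenoxycarbonyl in place of benzyl gives no sign of stronger inhibition (an at least 1.3-fold higher number from compound 2 to compound 4 (0.14 log units; that floor lies within the scatter)). Compound 1 and compound 4 both stand at a limit, so the step between them cannot be read: the limit of > 10000 nM in this assay, at which 2 of the 4 values shown sit.

As far as these compounds go, compound 3 has no reported result, so the effect of the methyl on the aromatic carbon remains open. Also open, from the compounds shown here alone, is how an amine or a carboxylic acid on the benzyl group of compound 2 would read.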